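From benzoyl to acetyl on the shared core

The source may report more compounds than this note shows. Statements on the series, on what has been measured and on what is new or still open speak of the compounds shown alone.

Measured so far in a functional assay on A549 cells (Homo sapiens) for cytotoxicity, read by MTT assay, with a stated time of 4 days (a lower number here means a stronger inhibitor, a higher number a weaker inhibitor), for two compounds
Compound 1 `COc1cc(C[C@H]2C(=O)OC[C@@H]2Cc2ccc(OC)c(OC)c2)ccc1N` gives 2850 nM as a measured number
Compound 2 `COc1cc(C[C@H]2C(=O)OC[C@@H]2Cc2ccc(OC)c(OC)c2)ccc1NC(=O)c1ccccc1` gives > 50000 nM as a limit of the assay

Compound 2 has no exact number: its > 50000 nM is a limit and nothing more. Compound 3 `COc1cc(C[C@H]2C(=O)OC[C@@H]2Cc2ccc(OC)c(OC)c2)ccc1NC(C)=O` keeps the amide but has methyl in place of phenyl on a carbonyl carbon and so goes from benzamido to acetamido. Among the compounds with values here, one measured step bears on this, the large change an at least 17-fold higher number from compound 1 to compound 2 (1.24 log units; beyond the scatter) when benzoyl replaced hydrogen on a nitrogen on an aromatic ring. Compound 3 also carries a group on that nitrogen, so a value between those of compound 1 and compound 2 is expected, probably nearer the limit. The expected step is an at least 2.7-fold lower number from compound 2 to compound 3 (0.44 log units; beyond the scatter) as an estimate, towards a lower number. The estimate for compound 3 is 18000 nM with an expected range from 5000 nM to 50000 nM in this assay when measured.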

Compound 3, half-maximal inhibitory concentration: > 50000 nM
Compound 3: no number, only a limit; the forecaster's own chance of this, stated with the estimate: 30%; middle value at least 2.7-fold (0.44 log units) from the limit.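

In this assay, adding acetyl to the nitrogen gives an at least 17-fold higher number from compound 1 to compound 3 (1.24 log units; beyond the scatter), so the loss of activity seen with benzoyl does not depend on the phenyl ring. Compound 3 gives > 50000 nM, which is a limit of the assay and not a number. The step from phenyl to methyl on a carbonyl carbon cannot be read, because compound 2 and compound 3 both stop at the same limit: the limit of > 50000 nM in this assay, at which 2 of the 3 values shown sit.

From the compounds shown here alone, how far the true values of compound 2 and compound 3 lie past that limit stays open, and so does any difference between them. Also open, going by these compounds, is whether a simple methyl placed directly on the nitrogen, with no carbonyl, would keep a measurable number like that of compound 1 or would also reach the limit.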